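Methyl on the dimethylphenyl amide ring; expected cytotoxicity

The compounds below may be only part of what the source reports. "The series", "measured", "known", "first", "only" and "open" are said of these compounds alone.

Measured compounds:
compound 1 `COc1cc2c(Nc3nc4ccc(C(=O)Nc5c(C)cccc5C)cc4s3)ncnc2cc1OCCCN1CCCC1` — 18900 nM
compound 2 `COc1cc2c(Nc3nc4ccc(C(=O)Nc5c(C)cccc5C)cc4s3)ncnc2cc1OCCCN1CCCCC1` — 14700 nM
compound 3 `COc1cc2c(Nc3nc4ccc(C(=O)Nc5c(C)cccc5C)cc4s3)ncnc2cc1OCCCN1CCC(C)CC1` — 11200 nM

In a functional assay on U-937 cells (Homo sapiens) for cytotoxicity, read by WST assay, with a stated time of 72 h (on this read-out higher numbers stand for weaker inhibition and lower numbers for stronger inhibition), compound 1 gives 18900 nM, the highest of the three numbers, but its nearest and furthest neighbours sit close: a 1.3-fold lower number from compound 1 to compound 2 (0.11 log units; within the scatter) and a 1.7-fold lower number from compound 1 to compound 3 (0.23 log units; within the scatter) both lie within the scatter, as does a 1.3-fold lower number from compound 2 to compound 3 (0.12 log units; within the scatter). Compound 4 `COc1cc2c(Nc3nc4ccc(C(=O)Nc5c(C)cc(C)cc5C)cc4s3)ncnc2cc1OCCCN1CCCC1` differs from compound 1 by methyl in place of hydrogen on an aromatic carbon. Within the data shown here, none of the measured steps touches the 2,6-dimethylphenyl ring; all three concern the amine at the end of the chain, and none of them moved the number in this assay beyond the scatter. Among the measured compounds shown here, with no step bearing on this ring, no shift beyond the scatter is expected for compound 4, and the estimated step is a 1.1-fold lower number from compound 1 to compound 4 (0.02 log units; within the scatter). Compound 4 is therefore expected to give 18000 nM in this assay, within a range from 7000 nM to 45000 nM.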

Compound 4, half-maximal inhibitory concentration: 4600 nM
For compound 4 the middle estimate is 3.9-fold (0.59 log units) above the measured one; the measured number lies below the stated range.
By their numbers in this assay, from the lowest: compound 4; then compounds 3, 2 and 1 (each within the scatter of the next).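

Going from 2,6-dimethylphenyl to 2,4,6-trimethylphenyl gives, in this assay, a 4.1-fold lower number from compound 1 to compound 4 (0.61 log units; beyond the scatter), the only step here beyond the scatter; the amine steps among compound 1, compound 2 and compound 3 all stay within it. The aromatic carbon para to the large group is therefore a place where a single added methyl moves this read-out. Nothing available accounts for this step.

Still open, on these data alone, is whether a methoxy, chlorine or ethyl on this carbon gives a similar step. Also open, as far as these compounds go, is whether the added methyl does the same with piperidin-1-yl or 4-methylpiperidin-1-yl on the chain.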